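The compounds below may be only part of what the source reports. "The series", "measured", "known", "first", "only" and "open" are said of these compounds alone.

Series of enol-ketone cinnamoyl cores carrying alkyl and alkoxy substituents, assessed in a functional assay on 1A9 cells (Homo sapiens) for antiproliferative activity, read by sulforhodamine B assay, with a stated time of 3 days; a higher number here means that more compound is needed for the effect, a lower number that less compound is needed.

Compound 1 `CCCOC1=C(CCC)C(=O)/C(=C(O)/C=C/c2ccccc2)C(=O)C1(CCC)CCC` gives 2 uM in this assay and stands at the lowest of the two numbers recorded so far. Compound 3 `CCCCC1=C(OC)C(CCCC)(CCCC)C(=O)/C(=C(O)\C=C\c2ccccc2)C1=O` gives 5.9 uM in this assay; the two structures differ in more than one place, so only the two values themselves are compared: the number for compound 3 is higher than that for compound 1, and the gap lies beyond the usual scatter. Compound 2 `CCCC1(CC=C(C)C)C(=O)C(C(=O)/C=C/c2ccccc2)=C(O)C(CCC)(CCC)C1=O` was included in the set, but for compound 2 the entry in this assay reads "not determined" (no result reported), so no result was reported for it.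

Compound 4 `CCCC1=C(OC)C(CCC)(CCC)C(=O)/C(=C(O)\C=C\c2ccccc2)C1=O` has not yet been measured. Relative to compound 1 the change is hydrogen in place of ethyl on a saturated chain carbon bound to an oxygen on an unsaturated carbon. For the measured compounds named here, no pair differing in one place has been measured, so no step of this kind is known. Compound 4 is expected to give a number in this assay close to that of compound 1, with at most a small rise, because compound 3, which also carries the methoxy, gives 5.9 uM. The step from compound 1 to compound 4 is estimated as a 1.5-fold higher number from compound 1 to compound 4 (0.18 log units; within the scatter), likely within or only just beyond the scatter. Compound 4 is accordingly estimated at 3 uM, with a range from 1.2 uM to 8 uM.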

Compound 4, concentration for half-maximal effect: 3.7 uM
Estimate against measurement, compound 4: 1.2-fold (0.09 log units) below, within the range that was stated.
By their numbers in this assay, from the lowest: compounds 1, 4 and 3 (each within the scatter of the next, the first and the last beyond it).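

In this assay, for the compounds shown here, the exchange of propoxy for methoxy, the one difference on the shared core, gives a 1.9-fold higher number from compound 1 to compound 4 (0.27 log units; within the scatter); this is the first pair that isolates this position, and the change stays inside the usual scatter. Within this pair, then, the propoxy group is not needed for a number at this level in this assay, and the loss of the ethyl from the chain leaves compound 4 not separable from compound 1. No measurement at hand bears on why the number holds across this change.

As far as these compounds go, whether this position also accepts a longer chain such as butoxy, or a different kind of group such as an amine or a carboxylic acid, remains open, and the methoxy-to-propoxy span says nothing about either. The other propyl chains of compound 4 also remain open, since no pair among the compounds shown differs at one of them alone.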